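The source may report more compounds than this note shows. Statements on the series, on what has been measured and on what is new or still open speak of the compounds shown alone.

Measured compounds in a functional assay on NCI-H460 cells (Homo sapiens) for cytotoxicity, read by MTT assay, with a stated time of 72 h; on this read-out higher numbers stand for weaker inhibition and lower numbers for stronger inhibition:
compound 1 `CN(C)CCn1cnnc1-c1cc(Oc2ccc(NC(=O)N/N=C/c3cccc(Cl)c3Cl)cc2F)ccn1` gives 72 nM
compound 2 `CN(C)CCn1cnnc1-c1cc(Oc2ccc(NC(=O)N/N=C/c3ccc(O)cc3)cc2F)ccn1` gives 1780 nM
compound 3 `CN(C)CCn1cnnc1-c1cc(Oc2ccc(NC(=O)N/N=C/c3cc(Br)c(O)c(Br)c3)cc2F)ccn1` gives 3760 nM

Compound 3 carries the highest number of the three and so shows the weakest inhibition in this assay: the step of a 2.1-fold higher number from compound 2 to compound 3 (0.32 log units; beyond the scatter) is modest, while a 52-fold higher number from compound 1 to compound 3 (1.72 log units; beyond the scatter) is large. Compound 4 `Cc1cc(/C=N/NC(=O)Nc2ccc(Oc3ccnc(-c4nncn4CCN(C)C)c3)c(F)c2)cc(C)c1O` differs from compound 3 at a single place: 4-hydroxy-3,5-dimethylphenyl in place of 3,5-dibromo-4-hydroxyphenyl on a carbon with a double bond to nitrogen. The change keeps the 4-hydroxyphenyl type of ring shared by compound 2 and compound 3 and exchanges bromine for methyl on it. The step that bears most directly is a 2.1-fold higher number from compound 2 to compound 3 (0.32 log units; beyond the scatter), which shows that going from 4-hydroxyphenyl to 3,5-dibromo-4-hydroxyphenyl moved the number only modestly; a 25-fold higher number from compound 1 to compound 2 (1.39 log units; beyond the scatter) and a 52-fold higher number from compound 1 to compound 3 (1.72 log units; beyond the scatter) show that the large loss in this part of the series comes with the 4-hydroxyphenyl type of ring rather than with the bromines of the 3,5-dibromo-4-hydroxyphenyl group. Among the measured compounds shown here, no measured compound carries a methyl on this ring, so the effect of the 4-hydroxy-3,5-dimethylphenyl group itself is untested. The expectation is therefore a step of a 1.5-fold lower number from compound 3 to compound 4 (0.18 log units; within the scatter), within the scatter, with compound 4 expected to remain in the weaker region occupied by compound 2 and compound 3. Compound 4 is estimated at 2500 nM in this assay, with a range of 900 nM to 7000 nM.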

Compound 4, half-maximal inhibitory concentration: 2010 nM
Compound 4: middle estimate off by 1.2-fold (0.09 log units), on the high side; low and high end bracket the measured number.
By their numbers in this assay, from the lowest: compound 1; then compounds 2, 4 and 3 (each within the scatter of the next, the first and the last beyond it).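

In this assay, bromine and methyl on the 4-hydroxyphenyl type of ring cannot be told apart at this position on a carbon with a double bond to nitrogen, with a 1.9-fold lower number from compound 3 to compound 4 (0.27 log units; within the scatter) as the exchange. Adding the two methyls to the 4-hydroxyphenyl group also stays inside the scatter, with a 1.1-fold higher number from compound 2 to compound 4 (0.05 log units; within the scatter) as the step, although the bromines gave a step just beyond it; the 4-hydroxy-3,5-dimethylphenyl group therefore cannot be separated from either neighbour. The gap to the 2,3-dichlorophenyl group persists with a third ring of this type, at a 28-fold higher number from compound 1 to compound 4 (1.45 log units; beyond the scatter) as the step, so compound 2, compound 3 and compound 4 all lie apart from compound 1 whether the ring carries bromine, methyl or neither, and no independent data bear on the reason for this.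

The series still does not separate the hydroxyl from the chlorines, since compound 1 differs from the others in both; a 4-methoxyphenyl, a 4-aminophenyl or a 2,3-dichloro-4-hydroxyphenyl group would address that. It also leaves open how a carboxylic acid or a single chlorine on this ring would read in this assay against the values seen so far.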